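A few compounds are considered here, and "the series" means these few. Any claim that something is new, unique, unknown or untested is made for them only; others in the source may bear on it.

Among the compounds with values here, compound 1 `OC[C@H]1O[C@@H](n2cnc3c(Cn4ccc5ccccc54)ncnc32)[C@H](O)[C@@H]1O` sits at the low end of the three numbers measured so far: in a functional assay on HL-60 cells (Homo sapiens) for inhibition, with a stated time of 72 h (a lower number here means a stronger inhibitor, a higher number a weaker inhibitor), compound 1 gives 5700 nM, compound 2 `OC[C@H]1O[C@@H](n2cnc3c(CSCc4ccccc4)ncnc32)[C@H](O)[C@@H]1O` gives 10700 nM and compound 3 `OC[C@H]1O[C@@H](n2cnc3c(CN4CCCCC4)ncnc32)[C@H](O)[C@@H]1O` gives 6900 nM, and all three lie within the scatter of one another. Compound 4 `COCc1ncnc2c1ncn2[C@@H]1O[C@H](CO)[C@@H](O)[C@H]1O` differs from compound 1 in a single place: methoxy in place of 1H-indol-1-yl on a saturated chain carbon bound to an aromatic carbon. The two measured steps that swapped the very same group, a 1.9-fold higher number from compound 1 to compound 2 (0.27 log units; within the scatter) and a 1.2-fold higher number from compound 1 to compound 3 (0.08 log units; within the scatter), both stayed within the scatter, so exchanging this group has not yet moved the numbers. Compound 4 is therefore expected to show a change no larger than the scatter, a 1.3-fold higher number from compound 1 to compound 4 (0.12 log units; within the scatter). Compound 4 is estimated at 7500 nM, within a range of 3000 nM to 20000 nM.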

Compound 4, half-maximal inhibitory concentration: 13000 nM
Compound 4: middle estimate off by 1.7-fold (0.24 log units), on the low side; measured number inside the range.
By their numbers in this assay, from the lowest: compounds 1, 3, 2 and 4 (each within the scatter of the next, the first and the last beyond it).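

Methoxy on this saturated chain carbon bound to an aromatic carbon gives the first step here that lies beyond the scatter, though a modest one (a 2.3-fold higher number from compound 1 to compound 4 (0.36 log units; beyond the scatter)). The other two steps to methoxy stay within the scatter (a 1.9-fold higher number from compound 3 to compound 4 (0.28 log units; within the scatter); a 1.2-fold higher number from compound 2 to compound 4 (0.08 log units; within the scatter)), so methoxy separates from 1H-indol-1-yl but not from piperidin-1-yl or benzylsulfanyl. No supporting measurement explains this difference.

Going by these compounds, whether a primary amine or a carboxylic acid on this carbon would lower the number or raise it further stays open. So does whether any group here can give a number clearly below that of compound 1.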